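Coumarin ethers: a bromoalkyl chain gives way to an amino alcohol

The source may hold more compounds than are shown below. What is called first, only, known or untested is meant among the compounds shown, and "the series" means these compounds.

Compound 1, `COc1cc2ccc(=O)oc2cc1OCC(O)CN1CCN(C)CC1`: 0.1%
Compound 2, `COc1cc2ccc(=O)oc2cc1OCCCCBr`: 11.2%
Compound 3, `COc1cc2ccc(=O)oc2cc1OCC(=O)c1ccc([N+](=O)[O-])cc1`: 4.1%

The three compounds share one core and differ only in the chain on the aryl ether oxygen. In a functional assay on HUVEC cells (Homo sapiens) for inhibition, read by MTT assay, with a stated time of 24 h, tested at 10 uM (a lower number here means less inhibition of growth, a higher number more inhibition of growth at the concentration tested), compound 2 gives 11.2%, and it stands at the top of the three numbers. Its gap to compound 3, which gives 4.1%, lies within the scatter, while its gap to compound 1, which gives 0.1%, lies beyond it.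

Compound 4, `COc1cc2ccc(=O)oc2cc1OCC(O)CNC(C)C`, has not been measured. It differs from compound 2 by 1-hydroxy-2-(isopropylamino)ethyl in place of 3-bromopropyl on a saturated chain carbon bound to an oxygen on an aromatic ring. Going by the values given here, no measured pair isolates this change. Compound 1 carries a chain of the same kind, a hydroxyl and a basic amine on the ether-linked chain, and its number is the lowest of the three.

Because compound 1 gives 0.1% with a related chain, compound 4 is expected to give 2% in this assay, within a range of -6% to 10%. The expected step of a number 9.2 percentage points lower from compound 2 to compound 4 (within the scatter) is downward and about the size of the scatter, perhaps just beyond it.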

Compound 4, percent growth inhibition at one concentration: 0.1%
Beside the measured number, compound 4's estimate is 1.9 percentage points above it; the measured number falls inside the stated range.
By their numbers in this assay, from the lowest: compounds 1, 4, 3 and 2 (each within the scatter of the next, the first and the last beyond it).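

In this assay, going by these compounds alone, this pair gives the first direct reading of the change at this position: 1-hydroxy-2-(isopropylamino)ethyl in place of 3-bromopropyl gives a number 11.1 percentage points lower from compound 2 to compound 4 (beyond the scatter) and so takes the number down to that of compound 1. The amine at the end of the chain makes no readable difference here, since isopropylamino in place of 4-methylpiperazin-1-yl gives no change at the digits printed from compound 1 to compound 4 (within the scatter) and leaves the two amino alcohols together at the low end of the series. Nothing measured here accounts for the loss seen on leaving the bromoalkyl chain.

The compounds shown leave open whether the hydroxyl or the amine goes with the lower number, as no chain here carries a hydroxyl without an amine or an amine without a hydroxyl. They also leave open how a shorter or longer bromoalkyl chain, or a chloroalkyl chain, would read in this assay at this position.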